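Fluoro for methyl across two related cores

The compounds below may be only part of what the source reports. "The series", "measured", "known", "first", "only" and "open" are said of these compounds alone.

Measured in an assay on RBL-1 cells for inhibition of Polyunsaturated fatty acid 5-lipoxygenase (Rattus norvegicus); on this read-out higher numbers stand for weaker inhibition and lower numbers for stronger inhibition:
compound 1, `Cc1cccc(N2CC(C)NC(=O)N2)c1`: 19000 nM
compound 2, `CC1CN(c2cccc(F)c2)NC(=O)N1`: 6300 nM
compound 3, `Cc1cccc(N2CC(C)NC(=O)N2)n1`: 3800 nM

Compound 1 and compound 2 share a core and differ in one place: fluoro in place of methyl on an aromatic carbon. This single exchange gives a 3.0-fold lower number from compound 1 to compound 2 (0.48 log units; beyond the scatter), a modest step that is nonetheless beyond the scatter.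

Compound 3 carries a different core; how the two cores differ is not broken down here. Compound 3 has the lowest number of the three measured compounds. Its value against compound 2 lies within the scatter, so no order between those two is claimed; against compound 1 the gap is beyond the scatter.

Compound 4, `CC1CN(c2cccc(F)n2)NC(=O)N1`, is not yet measured. It relates to compound 3 the way compound 2 relates to compound 1: fluoro in place of methyl on an aromatic carbon. The place is not identical, though: in compound 1 the exchange sits on a six-membered aromatic ring of carbon only, whereas in compound 3 it sits on a six-membered aromatic ring with 1 nitrogen, next to the ring nitrogen. It is therefore the same kind of change, not the same change.

For compound 4 a step of a 2.5-fold lower number from compound 3 to compound 4 (0.40 log units; beyond the scatter) in this assay is expected, resting on the single earlier case, a 3.0-fold lower number from compound 1 to compound 2 (0.48 log units; beyond the scatter), tempered for the different ring. For the measured compounds named here, only one precedent exists, and the surroundings of the place differ. The expectation is taken a little smaller than that precedent. The estimate for compound 4 is 1500 nM, with an expected range from 500 nM to 4500 nM.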

Compound 4, half-maximal inhibitory concentration: 6600 nM
For compound 4 the middle estimate is 4.4-fold (0.64 log units) below the measured one; the whole stated range lies below it.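

In this assay, fluoro in place of methyl on an aromatic carbon does not carry over unchanged from one core to the other: the same change on two cores in this assay, a 3.0-fold lower number (0.48 log units; beyond the scatter) from compound 1 to compound 2 and a 1.7-fold higher number (0.24 log units; within the scatter) from compound 3 to compound 4, 5.2-fold (0.72 log units) apart, beyond the scatter of two such steps

On the core with the ring nitrogen, the exchange gives a 1.7-fold higher number from compound 3 to compound 4 (0.24 log units; within the scatter), so the modest gain on the all-carbon aromatic ring does not recur there, and no order is claimed between the two compounds of this pair. This shows that the earlier step is a poor guide to the size of this exchange on the second core, but it does not show that fluoro is worse than methyl on that core, and with one pair per core it does not separate the part played by the ring nitrogen from any other difference between the cores.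

The compounds shown hold only methyl and fluoro at this place, so how chloro, methoxy or a nitrile would read on either core remains open. Also open, on these data alone, is whether a further methyl-to-fluoro pair on a six-membered aromatic ring with 1 nitrogen would track the pair of compound 3 and compound 4 or the pair of compound 1 and compound 2.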